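The source may hold more compounds than are shown below. What is called first, only, known or untested is meant among the compounds shown, and "the series" means these compounds.

Working notes on the series. The shared core carries a double-bonded nitrogen on its side chain in every member. Compound 1 `O=c1[nH]c2ccccc2cc1/C=N/CCO` and compound 2 `CCCC/N=C/c1cc2ccccc2[nH]c1=O` differ on that chain; in a functional assay, read by spectrophotometry, with a stated time of 5 min (a higher number here means a weaker inhibitor, a lower number a stronger inhibitor), compound 1 gives 467000 nM and compound 2 gives 246000 nM, and the step of a 1.9-fold lower number from compound 1 to compound 2 (0.28 log units; within the scatter) stays within the scatter. Compound 3 `Cc1ccc2[nH]c(=O)c(/C=N/Cc3ccccc3)cc2c1` gives 310000 nM in this assay, which sits within the usual scatter of compound 2 and of compound 1 alike, so the three measured numbers are not distinguished from one another.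

Compound 4 `O=c1[nH]c2ccccc2cc1/C=N/Cc1ccccc1` is the next member. The change from compound 3 to compound 4 is hydrogen in place of methyl on an aromatic carbon. Going by the values given here, no measured step touches the aromatic ring; the only measured step, from compound 1 to compound 2, alters the side chain and is itself within the scatter. There is therefore no basis in this assay for expecting a step beyond the scatter in either direction, and the estimated step of no change at the digits printed from compound 3 to compound 4 (within the scatter) is set at no change. Compound 4 is expected to give about 310000 nM, with a range from 130000 nM to 740000 nM.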

Compound 4, half-maximal inhibitory concentration: 329000 nM
Compound 4: middle estimate off by 1.1-fold (0.03 log units), on the low side; the range from low to high includes it.
By their numbers in this assay, from the lowest: compounds 2, 3, 4 and 1 (each within the scatter of the next).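

In this assay, going by these compounds alone, hydrogen in place of methyl on the aromatic carbon gives a 1.1-fold higher number from compound 3 to compound 4 (0.03 log units; within the scatter) and is the first measured step on this ring, so the methyl, meta to a fused ring and para to a fused ring, has no effect that can be told from the scatter. Compound 4 also links to the unsubstituted side-chain members: phenyl in place of propyl gives a 1.3-fold higher number from compound 2 to compound 4 (0.13 log units; within the scatter) and phenyl in place of hydroxymethyl gives a 1.4-fold lower number from compound 1 to compound 4 (0.15 log units; within the scatter) and neither step separates the compounds. Nothing measured here accounts for these results.

Going by these compounds, whether a carboxylic acid or an amine on that aromatic carbon would give a step beyond the scatter stays open. The same holds for a longer chain on the double-bonded nitrogen.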